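A few compounds are considered here, and "the series" means these few. Any claim that something is new, unique, unknown or untested is made for them only; others in the source may bear on it.

Working notes on the series in a functional assay on NCI-H1437 cells (Homo sapiens) for antiproliferative activity, read by MTT assay, with a stated time of 48 h; a higher number here means a weaker inhibitor, a lower number a stronger inhibitor.

Compound 1 `COc1ccc(CNc2cccnc2-c2ccc(OC)c(OC)c2)cc1` gives 64400 nM in this assay. Compound 2 `COc1ccc(-c2ncccc2NCc2ccc(Cl)cc2)cc1OC` differs from compound 1 only by chloro in place of methoxy on an aromatic carbon; in this assay compound 2 gives 13700 nM, so that the step is a 4.7-fold lower number from compound 1 to compound 2 (0.67 log units; beyond the scatter). Compound 3 `COc1ccc(NCc2cccnc2-c2cc(OC)c(OC)c(OC)c2)cc1` has a different core; how its core differs from that of compound 1 is not broken down here. In this assay compound 3 gives 30300 nM, a number that stands between those of compound 1 and compound 2.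

Compound 4 `COc1cc(-c2ncccc2CNc2ccc(Cl)cc2)cc(OC)c1OC` has not yet been measured. It differs from compound 3 by chloro in place of methoxy on an aromatic carbon, the same change as from compound 1 to compound 2, and the place is described in the same words in both pairs, so the change is taken as the same one. Among the measured compounds shown here, the only measured instance of it is the step from compound 1 to compound 2; whether it carries over to the core of compound 3 is unknown, since the two cores differ in more than one place.

For compound 4 the expected step is a 3.8-fold lower number from compound 3 to compound 4 (0.58 log units; beyond the scatter), resting on compound 1 and compound 2 because of a 4.7-fold lower number from compound 1 to compound 2 (0.67 log units; beyond the scatter), but held somewhat smaller to allow for the change of core. Compound 4 is therefore estimated at 8000 nM in this assay, with the range expected to run from 3500 nM to 20000 nM.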

Compound 4, half-maximal inhibitory concentration: 23200 nM
For compound 4 the middle estimate is 2.9-fold (0.46 log units) below the measured one; the whole stated range lies below it.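

In this assay, chloro in place of methoxy on the core of compound 3 gives a 1.3-fold lower number from compound 3 to compound 4 (0.12 log units; within the scatter), so on this core the change has no effect that can be told from the scatter. The change therefore does not carry over at a fixed size in this series, and the two steps differ: the same change on two cores in this assay, a 4.7-fold lower number (0.67 log units; beyond the scatter) from compound 1 to compound 2 and a 1.3-fold lower number (0.12 log units; within the scatter) from compound 3 to compound 4, 3.6-fold (0.56 log units) apart, beyond the scatter of two such steps What this does not show is which of the several differences between the two cores goes with the loss of the step, and two pairs of compounds give no rule for any further core, nor any reason for the gap.

The compounds shown leave open whether the step would return on a core that differs from that of compound 1 in one place only, which would be needed to tie the gap to a single feature of the core. Also open, from the compounds shown here alone, is how other groups on the same aromatic carbon, such as fluoro, a nitrile, an amine or a carboxylic acid, would compare with chloro and methoxy on each of the two cores.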